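A chlorophenyl swap on the amine nitrogen of compound 1

The source may report more compounds than this note shows. Statements on the series, on what has been measured and on what is new or still open speak of the compounds shown alone.

Compound 1 `CCOc1ccccc1NCn1nc(-c2ccc3c(c2)OCCO3)oc1=S` is the starting point of this account. Among the compounds with values here, in a functional assay, with a stated time of 6 min (on this read-out higher numbers stand for weaker inhibition and lower numbers for stronger inhibition), compound 1 gives 5280 nM, the lowest of the numbers measured so far. Compound 3 `S=c1oc(-c2ccc3c(c2)OCCO3)nn1CNc1cccc(Cl)c1` gives 6220 nM in this assay, and the difference a 1.2-fold higher number from compound 1 to compound 3 (0.07 log units; within the scatter) is within the scatter, so the two cannot be ordered. Compound 2 `S=c1oc(-c2ccc3c(c2)OCCO3)nn1CNC1CCCCC1` gives 18400 nM, and a 3.5-fold higher number from compound 1 to compound 2 (0.54 log units; beyond the scatter) is the one clear gap among the three, with a 3.0-fold lower number from compound 2 to compound 3 (0.47 log units; beyond the scatter) pointing the same way from the other side.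

Compound 4 `S=c1oc(-c2ccc3c(c2)OCCO3)nn1CNc1ccc(Cl)cc1` has not yet been measured. It differs from compound 1 in one place: 4-chlorophenyl in place of 2-ethoxyphenyl on an amine nitrogen. Within the data shown here, the step that bears most directly on this change is the one to compound 3, where a chlorophenyl also replaced 2-ethoxyphenyl on the amine nitrogen and a 1.2-fold higher number from compound 1 to compound 3 (0.07 log units; within the scatter) stayed within the scatter. Among the measured compounds shown here, the only step beyond the scatter, a 3.5-fold higher number from compound 1 to compound 2 (0.54 log units; beyond the scatter), involved cyclohexyl rather than a chlorophenyl and so speaks less to compound 4. Because a 1.2-fold higher number from compound 1 to compound 3 (0.07 log units; within the scatter) was flat, the expected step of a 1.1-fold higher number from compound 1 to compound 4 (0.06 log units; within the scatter) for compound 4 is small or none beyond the scatter. Compound 4 is therefore estimated at 6000 nM in this assay, with a range from 2500 nM to 14000 nM.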

Compound 4, half-maximal inhibitory concentration: 7270 nM
Estimate against measurement, compound 4: 1.2-fold (0.08 log units) below, and the stated range covers the measured number.
By their numbers in this assay, from the lowest: compounds 1, 3 and 4 (each within the scatter of the next); then compound 2.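

In this assay, within the data shown here, the two chlorophenyl groups on the amine nitrogen cannot be ordered, with a 1.2-fold higher number from compound 3 to compound 4 (0.07 log units; within the scatter) as the only comparison of this kind, so the position shows no readable preference between 3-chlorophenyl and 4-chlorophenyl. The change from 2-ethoxyphenyl to a chlorophenyl now stays flat for a second group, at a 1.4-fold higher number from compound 1 to compound 4 (0.14 log units; within the scatter) even though the group that leaves carries one hydrogen-bond acceptor and the group that enters carries none. The gap to the cyclohexyl compound also recurs, with a 2.5-fold lower number from compound 2 to compound 4 (0.40 log units; beyond the scatter) lying beyond the scatter, so all three compounds with a six-membered aromatic ring of carbon only on this nitrogen stand apart from the cyclohexyl compound, and none of the compounds shown goes against this, but nothing given here offers an explanation for either the flat steps or the gap.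

The compounds shown leave open whether this flatness would hold for a phenyl ring bearing a carboxylic acid or an amine, or for a pyridine ring on the same nitrogen. They also leave open whether the gap to cyclohexyl would persist with a smaller saturated ring such as cyclopropyl or with an open chain such as butyl.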